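A few compounds are considered here, and "the series" means these few. Any claim that something is new, unique, unknown or untested is made for them only; others in the source may bear on it.

Measured compounds in a functional assay on the whole organism (strain CD1) with Mus musculus as the target, with a stated time of 0.5 h; on this read-out lower numbers stand for an effect already at smaller amounts and higher numbers for an effect only at larger amounts of compound:
- compound 1 `CC1CC(=O)N(CC(=O)N2CCN(c3cccc(Cl)c3)CC2)C1=O`: compound 1 gives 100 mg/kg
- compound 2 `CC1CC(=O)N(CC(=O)N2CCN(c3ccc(Cl)c(Cl)c3)CC2)C1=O`: compound 2 gives 100 mg/kg

Within the data shown here, the single measured step in this assay, no change at the digits printed from compound 1 to compound 2 (within the scatter), puts compound 2 level with compound 1; the two values sit at the same digits, and no order between them can be read from this assay.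

Compound 3 `CC1CC(=O)N(CC(=O)N2CCN(c3ccccc3Cl)CC2)C1=O` is the next member of the series and has not yet been measured in this assay. Relative to compound 2 the change is 2-chlorophenyl in place of 3,4-dichlorophenyl on an amine nitrogen in a ring. Among the measured compounds shown here, the only step available for comparison is no change at the digits printed from compound 1 to compound 2 (within the scatter), which swapped chloro for hydrogen on the aromatic carbon without moving the read-out; no measured pair covers a shift of the chlorine to the position found in compound 3. For the measured compounds named here, on this thin basis, and with no step so far beyond the scatter, the expected step of no change at the digits printed from compound 2 to compound 3 (within the scatter) is none beyond the scatter. Compound 3 is therefore estimated at 100 mg/kg in this assay, with a range from 50 mg/kg to 200 mg/kg.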

Compound 3, minimum effective dose: 300 mg/kg
Compound 3: middle estimate off by 3.0-fold (0.48 log units), on the low side, outside the stated range (above it).
By their numbers in this assay, from the lowest: compounds 1 and 2 (each within the scatter of the next); then compound 3.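

In this assay, the phenyl group on the amine nitrogen in a ring now shows a sensitivity that the earlier pair did not: 2-chlorophenyl in place of 3,4-dichlorophenyl gives a 3.0-fold higher number from compound 2 to compound 3 (0.48 log units; beyond the scatter), and 2-chlorophenyl in place of 3-chlorophenyl gives a 3.0-fold higher number from compound 1 to compound 3 (0.48 log units; beyond the scatter). The second of these is the cleaner comparison, since it exchanges one named monochlorophenyl group for the other, so the placing of the chloro on the phenyl ring can move the read-out beyond the scatter, whereas the earlier step, no change at the digits printed from compound 1 to compound 2 (within the scatter), showed no such movement on going to 3,4-dichlorophenyl. Nothing at hand accounts for this shift towards larger amounts.

Going by these compounds, whether the higher number belongs to chloro specifically at the place it occupies in 2-chlorophenyl remains open, as a 2-fluorophenyl, 2-methylphenyl or 2-methoxyphenyl group could separate the placing from the identity of the group, and plain phenyl and 4-chlorophenyl would complete the comparison. Also open, on these data alone, is how the methyl group on the core of compound 1 contributes, which hydrogen or a longer chain in its place could address.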